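Swapping the amine on a shared core for an acetamidobenzylamine

This account rests on a few compounds, and the source may have more. Where it says the series, first, only, none or still open, it means among the compounds named here.

Compound 1 `CN(CC1CC1)CC1(O)CCN(CCCc2c[nH]c3ccc(-n4cnnc4)cc23)CC1` and compound 2 `CC1(C)CCCN(CC2(O)CCN(CCCc3c[nH]c4ccc(-n5cnnc5)cc34)CC2)C1` share one core and differ only in the amine attached to a saturated chain carbon bound to a saturated ring carbon. In a functional assay on CHO cells for agonist activity at 5-hydroxytryptamine receptor 1D (Homo sapiens), read by GTPgammaS binding (on this read-out lower numbers stand for an effect already at smaller amounts and higher numbers for an effect only at larger amounts of compound), compound 1 gives 1.1 nM, and in this assay compound 2 gives 0.9 nM. The step of a 1.2-fold lower number from compound 1 to compound 2 (0.09 log units; within the scatter) shows that replacing an open amine by a ring amine at this place left the number essentially unchanged, so compound 2 stands alongside compound 1 rather than apart from it.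

Compound 3 `CC(=O)Nc1ccc(CNCC2(O)CCN(CCCc3c[nH]c4ccc(-n5cnnc5)cc34)CC2)cc1` carries a different amine again: (4-acetamidobenzyl)amino in place of 3,3-dimethylpiperidin-1-yl on a saturated chain carbon bound to a saturated ring carbon. For the measured compounds named here, the only measured step that touches this position, a 1.2-fold lower number from compound 1 to compound 2 (0.09 log units; within the scatter), was within the scatter, which speaks for this place tolerating a change of amine. Going by the values given here, the entering group is larger and brings an aromatic ring and an amide, something no measured compound shows, so a modest rise in the number cannot be ruled out. The expected step of a 2.2-fold higher number from compound 2 to compound 3 (0.35 log units; beyond the scatter) is therefore small, and compound 3 is estimated at 2 nM, with a likely range from 0.5 nM to 8 nM.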

Compound 3, concentration for half-maximal effect: 14 nM
The estimate for compound 3 lay 7.0-fold (0.85 log units) below the measured number; the measured number lies above the stated range.
By their numbers in this assay, from the lowest: compounds 2 and 1 (each within the scatter of the next); then compound 3.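

In this assay, this place on a saturated chain carbon bound to a saturated ring carbon does not treat every amine alike: (4-acetamidobenzyl)amino gives a 16-fold higher number from compound 2 to compound 3 (1.19 log units; beyond the scatter) and a 13-fold higher number from compound 1 to compound 3 (1.10 log units; beyond the scatter), both large, although the two earlier amines gave numbers within the scatter of each other. The tolerance seen with compounds 1 and 2 therefore covers an open amine and a ring amine without aromatic ring or amide, but it does not extend to this larger group. No measurement shown here gives a reason for the rise.

The change brings in several things at once, an aromatic ring, an amide and a hydrogen on the amine nitrogen, so these compounds cannot say which of them goes with the higher number. A plain benzylamino group would show what the ring does without the acetamido part, and a (4-acetamidobenzyl)(methyl)amino group would show whether the hydrogen on the amine nitrogen matters.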